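The compounds below may be only part of what the source reports. "The series", "measured", "known", "first", "only" and "open" are said of these compounds alone.

Compound 1 `O=C(c1ccc(F)cc1)N1CCc2nc(COc3ccc(F)cc3)oc2C1` reaches 73% in a functional assay on HEK293 cells for positive allosteric modulation of metabotropic glutamate receptor 5 (Homo sapiens), read by calcium flux; on this read-out higher numbers stand for larger maximal responses and lower numbers for smaller maximal responses. Compound 2 `O=C(c1ccc(F)cc1)N1CCc2nc(COc3ccc(F)c(F)c3)oc2C1` differs from it only by fluoro in place of hydrogen on an aromatic carbon and gives 40%, so the step of a number 33 percentage points lower from compound 1 to compound 2 (beyond the scatter) is a clear loss. Compound 3 `O=C(c1cccc(F)c1)N1CCc2nc(COc3cccc(F)c3)oc2C1` has the same atoms as compound 1 joined differently; the difference between the two cores is not broken down here. In this assay compound 3 gives 75%, and against compound 1 this lies within the scatter, so the two cannot be separated.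

Compound 4 `O=C(c1cccc(F)c1F)N1CCc2nc(COc3cccc(F)c3)oc2C1` is compound 3 with fluoro in place of hydrogen on an aromatic carbon. This is the same kind of change as from compound 1 to compound 2, yet not the same: there the new fluoro sat meta to a large group, here it sits ortho to a large group, and on a different ring of the molecule. For the measured compounds named here, the one measured example of this kind of change is the loss in the step from compound 1 to compound 2, so a loss is expected here too, though with less confidence because the surroundings differ. The estimated step is a number 23 percentage points lower from compound 3 to compound 4 (beyond the scatter). For compound 4 the expected value is 52%, between 28% and 78%.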

Compound 4, largest response reached (reported as percent of maximum), in percent of the reference or control that the assay uses: 72%
Estimate against measurement, compound 4: 20 percentage points below; the range from low to high includes it.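

Fluoro in place of hydrogen on an aromatic carbon does not have one fixed effect across this series. In this assay, adding fluoro to give the 2,3-difluorophenyl group brings no measurable loss, with a number 3 percentage points lower from compound 3 to compound 4 (within the scatter), and this result does not match the earlier pair: the same change on two cores in this assay, a number 33 percentage points lower (beyond the scatter) from compound 1 to compound 2 and a number 3 percentage points lower (within the scatter) from compound 3 to compound 4, 30 percentage points apart, beyond the scatter of two such steps So a loss seen on one core cannot simply be assumed on another, but these two pairs do not show what produces the difference, as the new fluoro sits on a different ring and in a different place in each pair, and the cores are not the same either.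

The compounds shown carry only fluoro as a ring substituent, so it remains open whether chloro, methoxy or nitrile at the same ring positions would follow the pattern of compound 2 or that of compound 4. Going by these compounds, it also remains open whether adding fluoro to the other ring of compound 3 would give a loss like that seen for compound 2.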